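Removing the Substituent of Compound 3: An Expected Exposure

The compounds below may be only part of what the source reports. "The series", "measured", "known", "first", "only" and "open" are said of these compounds alone.

Three compounds have been measured in an ADME assay on the whole organism (Macaca fascicularis) for pharmacokinetics, read by LC-MS, using cassette dosing, at a dose of 1 mg/kg by the oral route; a lower number here means less compound in the circulation, a higher number more compound in the circulation at the dose given:

Compound 1, `CCCCN(c1nc2c(C(=O)N(C)C)cccc2o1)[C@H](C)c1ccc(-c2ccccc2-c2nnn[nH]2)cc1`, gives 104 ng.h/mL.
Compound 2, `CCCCN(c1nc2c(-c3nccn3C)cccc2o1)[C@H](C)c1ccc(-c2ccccc2-c2nnn[nH]2)cc1`, gives 152 ng.h/mL.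
Compound 3, `CCCCN(c1nc2c(C(=O)NS(C)(=O)=O)cccc2o1)[C@H](C)c1ccc(-c2ccccc2-c2nnn[nH]2)cc1`, gives 22.2 ng.h/mL.

Compound 3 stands lowest of the three. The steps of a 4.7-fold lower number from compound 1 to compound 3 (0.67 log units; beyond the scatter) and a 6.8-fold lower number from compound 2 to compound 3 (0.84 log units; beyond the scatter) both run downward and both lie beyond the scatter, while the step of a 1.5-fold higher number from compound 1 to compound 2 (0.16 log units; within the scatter) stays within the scatter, so the two compounds without the (methylsulfonyl)carbamoyl group sit together above compound 3.

Compound 4, `CCCCN(c1nc2ccccc2o1)[C@H](C)c1ccc(-c2ccccc2-c2nnn[nH]2)cc1`, has not yet been measured in this assay. Its difference from compound 3 is hydrogen in place of (methylsulfonyl)carbamoyl on an aromatic carbon. Among the measured compounds shown here, no measured step removes a group from this position altogether; the steps that bear on the change are the two that exchange the (methylsulfonyl)carbamoyl group for another group, and both gave a modest rise away from compound 3. On that basis compound 4 is expected to move upward in this assay, by a step estimated as a 5.4-fold higher number from compound 3 to compound 4 (0.73 log units; beyond the scatter), landing near the values of compounds 1 and 2. The estimate for compound 4 is 120 ng.h/mL, with a range from 40 ng.h/mL to 360 ng.h/mL.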

Compound 4, area under the concentration-time curve: 44.3 ng.h/mL
Estimate against measurement, compound 4: 2.7-fold (0.43 log units) above; measured number inside the range.
By their numbers in this assay, from the lowest: compounds 3 and 4 (each within the scatter of the next); then compounds 1 and 2 (each within the scatter of the next).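

In this assay, among the compounds shown here, hydrogen in place of (methylsulfonyl)carbamoyl on the aromatic carbon gives a 2.0-fold higher number from compound 3 to compound 4 (0.30 log units; within the scatter), so the compound carrying only hydrogen there does not separate from the one carrying that group. The two other exchanges do separate: hydrogen in place of dimethylcarbamoyl gives a 2.3-fold lower number from compound 1 to compound 4 (0.37 log units; beyond the scatter), and hydrogen in place of 1-methyl-1H-imidazol-2-yl gives a 3.4-fold lower number from compound 2 to compound 4 (0.54 log units; beyond the scatter). The earlier compounds shown here alone could be read as the (methylsulfonyl)carbamoyl group lowering the number, but with hydrogen as the reference, the difference at this position lies with the dimethylcarbamoyl and 1-methyl-1H-imidazol-2-yl groups, which both stand above it.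

Nothing shown here accounts for why these groups stand apart from hydrogen and the (methylsulfonyl)carbamoyl group. On these data alone, it remains open whether other groups on this aromatic carbon, such as a primary amide, a carboxylic acid, an amine or another five-membered ring containing nitrogen, would stand with compound 4 or with compound 1.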